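The compounds below may be only part of what the source reports. "The series", "measured", "known", "first", "only" and "open" are said of these compounds alone.

Compound 1 `Nc1scc(CN2CCN(c3cccc(C(F)(F)F)c3)CC2)c1C(=O)c1ccc(Cl)cc1`: -80%
Compound 2 `Nc1scc(CN2CCN(c3cccc(F)c3F)CC2)c1C(=O)c1ccc(Cl)cc1`: -79%

In a functional assay on CHO cells with adenosine receptor A1 (Homo sapiens) as the target, read by cAMP accumulation and immunoassay, with a stated time of 6 min, tested at 10 uM (on this read-out higher numbers stand for a weaker effect at the one concentration tested and lower numbers for a stronger effect), compound 1 gives -80% and compound 2 gives -79%. Going by the values given here, compound 2 thus stands within the scatter of compound 1, the only other measured compound, and the one measured step, a number 1 percentage points higher from compound 1 to compound 2 (within the scatter), lies within the scatter.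

Compound 3 `Nc1scc(CN2CCN(c3cc(F)ccc3F)CC2)c1C(=O)c1ccc(Cl)cc1` has not been measured. It differs from compound 2 by 2,5-difluorophenyl in place of 2,3-difluorophenyl on an amine nitrogen in a ring. Among the compounds with values here, the only step that bears on this change is the one from compound 1 to compound 2, which also exchanged the ring on that same amine nitrogen and gave a number 1 percentage points higher from compound 1 to compound 2 (within the scatter). Since that exchange moved the read-out by no more than the scatter, a step of about a number 4 percentage points higher from compound 2 to compound 3 (within the scatter) in this assay is expected for compound 3, that is, none beyond the scatter. Compound 3 is therefore estimated at -75%, with a range from -95% to -45%.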

Compound 3, a percentage reported as activity, at one concentration (the size of the read-out at that concentration, not a potency): -80%
Estimate against measurement, compound 3: 5 percentage points above, and the stated range covers the measured number.
By their numbers in this assay, from the lowest: compounds 1, 3 and 2 (each within the scatter of the next).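

In this assay, going by these compounds alone, 2,5-difluorophenyl in place of 2,3-difluorophenyl on the amine nitrogen in the ring gives a number 1 percentage points lower from compound 2 to compound 3 (within the scatter), and this is the first step here that keeps the atoms of the group and alters only how they are joined. Against 3-(trifluoromethyl)phenyl, the same group gives no change at the digits printed from compound 1 to compound 3 (within the scatter), so all three substituted phenyl groups at this amine nitrogen now read alike at the one concentration tested. Nothing at hand explains this likeness.

From the compounds shown here alone, whether a phenyl carrying an amine or a carboxylic acid, or a longer chain in place of the phenyl on this nitrogen, would read the same remains open. So does whether these three compounds would also read alike at other concentrations, as a single concentration gives no potency.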